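This account rests on a few compounds, and the source may have more. Where it says the series, first, only, none or still open, it means among the compounds named here.

In an in vivo ADME assay on the whole organism (strain 129/SvEvBrd x C57BL/6) for pharmacokinetics, with Mus musculus as the target, at a dose of 1 mg/kg by the intravenous route (on this read-out higher numbers stand for fast clearance and lower numbers for slow clearance), the measured compounds give these values:

Compound 1 `CC(=O)c1ncc([C@@H](O)[C@H](O)[C@H](O)CO)s1` gives 11.7 mL/min/kg
Compound 2 `CC(=O)c1nc([C@@H](O)[C@H](O)[C@H](O)CO)c(C)[nH]1` gives 7 mL/min/kg
Compound 3 `CN(C)C(=O)c1nc([C@@H](O)[C@H](O)[C@H](O)CO)c[nH]1` gives 11.3 mL/min/kg

Compound 3 at 11.3 mL/min/kg lies within the usual scatter of both compound 1 and compound 2, so it cannot be ranked against either. Among the measured compounds shown here, the one change in compound 4 `OC[C@@H](O)[C@@H](O)[C@H](O)c1c[nH]c(-c2ncccn2)n1` is pyrimidin-2-yl in place of dimethylcarbamoyl on an aromatic carbon between two ring nitrogen atoms (pyrimidin-2-yl in place of dimethylcarbamoyl on an aromatic carbon). For the measured compounds named here, no measured pair differs in just one place, so no direct guide exists. Compound 1 at 11.7 mL/min/kg and compound 2 at 7 mL/min/kg also stay within the scatter of each other, despite their different cores. A change in this assay no larger than the scatter is therefore expected, in either direction. The estimated step (a 1.1-fold higher number from compound 3 to compound 4 (0.03 log units; within the scatter)) is expected to be small. For compound 4 the expected clearance is estimated at 12 mL/min/kg (range 5 mL/min/kg to 25 mL/min/kg).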

Compound 4, clearance: 15.2 mL/min/kg
Estimate against measurement, compound 4: 1.3-fold (0.10 log units) below; the measured number falls inside the stated range.
By their numbers in this assay, from the lowest: compounds 2, 3, 1 and 4 (each within the scatter of the next, the first and the last beyond it).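

In this assay, putting pyrimidin-2-yl in place of dimethylcarbamoyl on this aromatic carbon between two ring nitrogen atoms gives a 1.3-fold higher number from compound 3 to compound 4 (0.13 log units; within the scatter). This is the only comparison shown that changes a single place, and it shows that this position can carry an aromatic ring instead of dimethylcarbamoyl with no readable shift in clearance. No data at hand give a reason for this result. From the compounds shown here alone, whether an amine or a carboxylic acid at this position would also leave clearance within the scatter remains open. So does whether this step would hold on the core of compound 1.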